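The source may hold more compounds than are shown below. What is called first, only, known or untested is meant among the compounds shown, and "the series" means these compounds.

The measured compounds:
compound 1 `COC(=O)/C=C/c1cccc(N(Cc2ccc(-c3ccc(F)c(Cl)c3)cc2)C(=O)C2CCCCC2)c1`, 66 nM
compound 2 `COC(=O)/C=C/c1cccc(N(Cc2cccc(Br)c2)C(=O)C2CCCCC2)c1`, a limit, > 1000 nM
compound 3 `CCOC(=O)/C=C/c1ccc(CN(C(=O)C2CCCCC2)c2cccc(/C=C/C(=O)OC)c2)cc1`, a limit, > 1000 nM

In an assay on isolated protein with Bile acid receptor (Homo sapiens) as the target (a lower number here means that less compound is needed, a higher number that more compound is needed for the effect), compound 1 gives 66 nM. For compound 2 this assay reports only a limit, > 1000 nM. For compound 3 this assay likewise reports only a limit, > 1000 nM. Compound 3 therefore stands at the upper edge of what is shown, one of the compounds sitting at the limit of > 1000 nM in this assay, at which 2 of the 3 values shown sit, with no number of its own. Among the measured compounds shown here, the only measured step that reaches compound 3 is an at least 15-fold higher number from compound 1 to compound 3 (1.18 log units; beyond the scatter), a large loss that ends at the limit.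

Compound 4 `COC/C=C/c1ccc(CN(C(=O)C2CCCCC2)c2cccc(/C=C/C(=O)OC)c2)cc1` differs from compound 3 in one place: methoxymethyl in place of ethoxycarbonyl on a double-bonded chain carbon bound to a double-bonded chain carbon. For the measured compounds named here, no measured step alters this group, so the size of this step cannot be read from the measurements; the neighbouring step an at least 15-fold higher number from compound 1 to compound 3 (1.18 log units; beyond the scatter) concerns a different position and shows only that compound 3 is at the limit. Compound 3 is already there, and the step expected is a step that the limit leaves unreadable from compound 3 to compound 4, a stay at or near the limit. The estimate for compound 4 in this assay is 3000 nM, in the range 800 nM to 20000 nM, with a real chance that only a limit is reported again.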

Compound 4, half-maximal effective concentration: 233 nM
Compound 4: the middle estimate sits 13-fold (1.11 log units) above what was measured; the whole stated range lies above it.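

At this place, on a double-bonded chain carbon bound to a double-bonded chain carbon, the ethoxycarbonyl group is not required for a readable value in this assay: methoxymethyl in its stead gives an at least 4.2-fold lower number from compound 3 to compound 4 (0.63 log units; beyond the scatter). So a small change at the end of this chain can lift a compound off the limit, which the earlier compounds did not show. Setting 4-(3-methoxyprop-1-en-1-yl)phenyl in place of 3-bromophenyl gives an at least 4.2-fold lower number from compound 2 to compound 4 (0.63 log units; beyond the scatter), and this step and the one before it are minimum sizes only, as each starts from a limit and not from a number: the limit of > 1000 nM in this assay, at which 2 of the 4 values shown sit. Even so, the new chain does not fully match the aromatic group of compound 1, as 3-methoxyprop-1-en-1-yl in place of 3-chloro-4-fluorophenyl gives a 3.5-fold higher number from compound 1 to compound 4 (0.55 log units; beyond the scatter).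

As far as these compounds go, what a carboxylic acid, a hydroxymethyl group or a longer ether chain would do at this same place remains open. Also open, from the compounds shown here alone, is whether the gain comes from the loss of the carbonyl or from the shorter chain, as these two differences arrive together in compound 4.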